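The source may hold more compounds than are shown below. What is called first, only, known or untested is meant among the compounds shown, and "the series" means these compounds.

Among the compounds with values here, only two compounds have been tested so far in a functional assay on HCT-116 cells (Homo sapiens) for cytotoxicity; on this read-out lower numbers stand for stronger inhibition and higher numbers for weaker inhibition. In it, compound 1 `CCCCCCCCCCCCC/C=C/C1=N[C@@H]1C(=O)OC` gives 18200 nM and compound 2 `COC(=O)[C@@H]1N=C1/C=C/CCCCCCCCC/C=C(/Cl)Br` gives 15200 nM. Within the data shown here, these numbers lie within the usual scatter of each other, so compound 1 stands level with the only other compound measured.

Compound 3 `COC(=O)[C@H]1N=C1/C=C/CCCCCCCCCC=C(Cl)Cl` has yet to be measured. The change from compound 1 is 2,2-dichloroethenyl in place of butyl on a saturated chain carbon, nine bonds along the chain from a double-bonded chain carbon. Among the measured compounds shown here, no measured pair shows this change on its own, so the evidence is thin. Compound 2, which also carries halogen atoms on its chain, gives 15200 nM, so no step beyond the scatter is expected in this assay, and no direction can be favoured. The estimated change is a 1.1-fold lower number from compound 1 to compound 3 (0.06 log units; within the scatter). Compound 3 is expected at 16000 nM, with an estimated range of 6000 nM to 40000 nM.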

Compound 3, half-maximal inhibitory concentration: 24800 nM
For compound 3 the middle estimate is 1.6-fold (0.19 log units) below the measured one, within the range that was stated.
By their numbers in this assay, from the lowest: compounds 2, 1 and 3 (each within the scatter of the next).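

In this assay, placing 2,2-dichloroethenyl in place of butyl on a saturated chain carbon, nine bonds along the chain from a double-bonded chain carbon, gives a 1.4-fold higher number from compound 1 to compound 3 (0.13 log units; within the scatter) and so shows no real shift. Within the data shown here, this is the first direct comparison at this position, and it shows that the position can carry two chlorine atoms and a double bond instead of a plain saturated end without the cell read-out leaving normal repeat variation. Nothing available explains this result.

On these data alone, it remains open whether a different group at this position, such as an amine, a carboxylic acid or a longer chain, would move the number beyond the scatter. These compounds also leave open how far a change to the shared core would matter.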